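A few compounds are considered here, and "the series" means these few. Any claim that something is new, unique, unknown or untested is made for them only; others in the source may bear on it.

Compound 1 `Cc1ccc(OCC(=O)N(Cc2cccs2)c2ccnn2C)cc1` is one of three related compounds tested in an assay on HEK293 cells for agonist activity at transient receptor potential cation channel subfamily M member 8 (Homo sapiens), read by fluorescence and calcium flux, with a stated time of 15 min; a higher number here means that more compound is needed for the effect, a lower number that less compound is needed. In this assay compound 1 gives 422 nM, the lowest of the two numbers reported. Compound 2 `CCN(Cc1cccs1)C(=O)COc1ccccc1` gives 1400 nM in this assay, a higher number that lies beyond the usual scatter, so compound 1 needs less compound for the same effect than compound 2 does. Compound 3 `Cc1ccc(OC2CCN(Cc3cccs3)C2=O)cc1` was reported in this assay as "not active" (no number reported), without a number.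

Compound 4 `Cc1ccc(OCC(=O)N(Cc2cccs2)c2cccnc2)cc1` has not yet been measured. It differs from compound 1 in one place: pyridin-3-yl in place of 1-methyl-1H-pyrazol-5-yl on an amide-type nitrogen. No measured pair among these three compounds shows this change, so its effect cannot be read from the data. In both compound 1 and compound 4 the amide-type nitrogen carries one aromatic ring. Only a modest shift is expected. Compound 4 is expected to give about 650 nM in this assay, within a range from 200 nM to 2000 nM. The estimated step of a 1.5-fold higher number from compound 1 to compound 4 (0.19 log units; within the scatter) is a small rise in the number, close to the scatter.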

Compound 4, half-maximal effective concentration: 198 nM
Compound 4: the middle estimate sits 3.3-fold (0.52 log units) above what was measured; the measured number lies below the stated range.
By their numbers in this assay, from the lowest: compound 4; then compound 1; then compound 2.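

Within the data shown here, replacing 1-methyl-1H-pyrazol-5-yl with pyridin-3-yl on the amide-type nitrogen gives a 2.1-fold lower number from compound 1 to compound 4 (0.33 log units; beyond the scatter) in this assay, the only direct reading of a change at this place, as the earlier compounds offered no pair differing in one place. The effect therefore does not depend on having the five-membered aromatic ring with 2 hetero atoms here, and a six-membered aromatic ring with 1 hetero atom serves at least as well. No measurement of any property of these two groups accompanies the result, so the data offer no explanation for the step.

The compounds shown do not reveal whether the ring nitrogen of pyridin-3-yl matters, which a plain phenyl ring at this place would test. They also leave open how pyridin-2-yl, pyridin-4-yl or an amine on the pyridin-3-yl ring would fare.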